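Shifting the attachment point on a heteroaromatic cap

The source may hold more compounds than are shown below. What is called first, only, known or untested is meant among the compounds shown, and "the series" means these compounds.

Measured so far:
Compound 1 `O=C(Nc1noc2ccccc12)N1CCN(Cc2cccc(Oc3ccc(Cl)cc3)c2)CC1` gives 10 nM in an assay on isolated protein for inhibition of Fatty-acid amide hydrolase 1 (Homo sapiens), with a stated time of 60 min; on this read-out lower numbers stand for stronger inhibition and higher numbers for weaker inhibition.
Compound 2 `O=C(Nc1noc2ccncc12)N1CCN(Cc2cccc(Oc3ccc(Cl)cc3)c2)CC1` gives 180 nM in this assay.
Compound 3 `O=C(Nc1cccn2ccnc12)N1CCN(Cc2cccc(Oc3ccc(Cl)cc3)c2)CC1` gives 310 nM in this assay.

All three compounds share the same chlorophenoxy-benzyl piperazine urea, and differ only in the bicyclic aromatic cap on the urea nitrogen. Compound 3 has the highest number of the three: the step of a 31-fold higher number from compound 1 to compound 3 (1.49 log units; beyond the scatter) is large, while the step of a 1.7-fold higher number from compound 2 to compound 3 (0.24 log units; within the scatter) is small and stays within the usual scatter.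

Compound 4 `O=C(Nc1ccn2ccnc2c1)N1CCN(Cc2cccc(Oc3ccc(Cl)cc3)c2)CC1` has not yet been measured. It keeps the same atoms as compound 3 but joins them differently: a group of 9 heavy atoms (7 carbon, 2 nitrogen; one five-membered aromatic ring with 2 hetero atoms, one six-membered aromatic ring with 1 hetero atom) in place of a group of 9 heavy atoms (7 carbon, 2 nitrogen; one five-membered aromatic ring with 2 hetero atoms, one six-membered aromatic ring with 1 hetero atom), on an amide-type nitrogen. Among the measured compounds shown here, no measured step bears directly on this kind of rearrangement; the two measured steps of an 18-fold higher number from compound 1 to compound 2 (1.26 log units; beyond the scatter) and a 31-fold higher number from compound 1 to compound 3 (1.49 log units; beyond the scatter) both replace the cap of compound 1 with a nitrogen-containing cap and both are large, whereas the step between the two nitrogen-containing caps is small. Since compound 4 carries a nitrogen-containing cap of the same composition as compound 3, no step beyond the scatter in this assay is expected, in either direction.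

Compound 4 is therefore estimated at 250 nM, with a range from 80 nM to 800 nM, an expected step of a 1.2-fold lower number from compound 3 to compound 4 (0.09 log units; within the scatter).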

Compound 4, half-maximal inhibitory concentration: 33 nM
Beside the measured number, compound 4's estimate is 7.6-fold (0.88 log units) above it; the measured number lies below the stated range.
By their numbers in this assay, from the lowest: compound 1; then compound 4; then compounds 2 and 3 (each within the scatter of the next).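

In this assay the atoms of a cap do not settle the result: the same atoms in the same kinds of ring, joined differently on the same amide-type nitrogen, give a 9.4-fold lower number from compound 3 to compound 4 (0.97 log units; beyond the scatter) as the outcome. A hetero atom in the six-membered ring also does not by itself place a cap at the weak end of the series, since compound 2, compound 3 and compound 4 all have one, and yet the comparison with the cap of compound 2 shows a 5.5-fold lower number from compound 2 to compound 4 (0.74 log units; beyond the scatter) as well. The cap of compound 1, whose six-membered ring is carbon only, still gives the lowest number, but a 3.3-fold higher number from compound 1 to compound 4 (0.52 log units; beyond the scatter) is a smaller step than those leading to the caps of compound 2 and compound 3.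

Nothing in the available data explains why this rearrangement of the cap changes the number.

Going by these compounds, it also remains open whether the cap of compound 4 would keep its standing with a small substituent such as a methyl group, an amine or a carboxylic acid on its six-membered ring.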